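Methyl to Fluoro on the Shared Core

The source may hold more compounds than are shown below. What is called first, only, known or untested is meant among the compounds shown, and "the series" means these compounds.

Compound 1 `Cc1ccc2nc(Nc3ccnc(Nc4ccc(S(C)(=O)=O)cc4)n3)sc2c1` was tested in a functional assay on PC-3 cells (Homo sapiens) for antiproliferative activity, read by MTT assay, with a stated time of 48 h; a lower number here means a stronger inhibitor, a higher number a weaker inhibitor. In this assay compound 1 gives only a limit, > 50000 nM, so where it truly stands is not known. Compound 2 `Cc1ccc2nc(Nc3ccnc(Nc4ccc(S(N)(=O)=O)cc4)n3)sc2c1` differs from it at a sulfonyl sulfur, and in this assay compound 2 gives 1640 nM. The step between them is an at least 30-fold lower number from compound 1 to compound 2 (1.48 log units; beyond the scatter), but it rests on the limit of > 50000 nM in this assay, at which 1 of the 2 values shown sits, and therefore only sets a floor on the change. Compound 3 `CS(=O)(=O)c1ccc(Nc2nccc(Nc3nc4ccc(F)cc4s3)n2)cc1` is the compound still to be measured. Its change from compound 1 is fluoro in place of methyl on an aromatic carbon. For the measured compounds named here, no measured step touches this place on the core; the single measured step concerns a different part of the molecule, so it offers no direct guide. With compound 1 sitting at a limit and a small change, the expected step is a number no higher from compound 1 to compound 3 (the limit leaves the size open). For compound 3 the estimate in this assay is 50000 nM, within 10000 nM to 150000 nM, with a fair chance that only a limit is reported again.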

Compound 3, half-maximal inhibitory concentration: 1940 nM
The estimate for compound 3 lay 26-fold (1.41 log units) above the measured number, and the stated range ends above it.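

In this assay fluoro in place of methyl on this aromatic carbon gives an at least 25-fold lower number from compound 1 to compound 3 (1.41 log units; beyond the scatter) even though one heavy atom simply replaces another. This shows that the read-out responds to a change on the shared core at this carbon, which the earlier step at the sulfonyl sulfur could not show. The size of the new step is only a floor, and the true change may be larger: the limit of > 50000 nM in this assay, at which 1 of the 3 values shown sits.

As far as these compounds go, whether the drop comes from fluoro itself or from the loss of methyl stays open, and a chlorine or a bare hydrogen at this carbon would help separate the two. Also open, from the compounds shown here alone, is whether fluoro on this carbon and amino on the sulfonyl sulfur would add together in one molecule.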